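Urea analogues on breast cancer cells: a closer look

The source may hold more compounds than are shown below. What is called first, only, known or untested is meant among the compounds shown, and "the series" means these compounds.

Three compounds have been measured so far in a functional assay on MDA-MB-231 cells (Homo sapiens) for cytotoxicity, read by MTT assay, with a stated time of 48 h; a lower number here means a stronger inhibitor, a higher number a weaker inhibitor:

compound 1, `O=C(NCCCCC(c1ccc(F)cc1)c1ccc(F)cc1)Nc1ccc(I)cc1`, gave 11800 nM
compound 2, `O=C(NCCCCC(c1ccc(F)cc1)c1ccc(F)cc1)Nc1ccc(Cl)c(C(F)(F)F)c1`, gave 3150 nM
compound 3, `O=C(NCCCCN(c1ccc(F)cc1)c1ccc(F)cc1)Nc1ccc(I)cc1`, gave only a limit of the assay, > 20000 nM

Compound 1 and compound 2 share a core and differ in one place: 4-chloro-3-(trifluoromethyl)phenyl in place of 4-iodophenyl on an amide-type nitrogen. In this assay that change produced a 3.7-fold lower number from compound 1 to compound 2 (0.57 log units; beyond the scatter). Compound 3 rests on a different core; how its core differs from that of compound 1 is not broken down here. For compound 3 the assay returned no number but (the limit of > 20000 nM in this assay, at which 1 of the 3 values shown sits).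

Compound 4, `O=C(NCCCCN(c1ccc(F)cc1)c1ccc(F)cc1)Nc1ccc(Cl)c(C(F)(F)F)c1`, awaits measurement. It differs from compound 3 in one place: 4-chloro-3-(trifluoromethyl)phenyl in place of 4-iodophenyl on an amide-type nitrogen. The place is the same, word for word, as in the change from compound 1 to compound 2, so this is the same change made a second time, on the other core.

The expectation for compound 4 rests on a single precedent, the step of a 3.7-fold lower number from compound 1 to compound 2 (0.57 log units; beyond the scatter), and on the fact that compound 3 offers only a limit, so the starting point is itself uncertain. The estimate amounts to an at least 1.6-fold lower number from compound 3 to compound 4 (0.22 log units; that floor lies within the scatter), and it is expected that the assay may again report only a limit. Compound 4 is expected to give about 12000 nM in this assay, within a range from 4000 nM to 40000 nM.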

Compound 4, half-maximal inhibitory concentration: 5040 nM
Beside the measured number, compound 4's estimate is 2.4-fold (0.38 log units) above it, within the range that was stated.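

In this assay, putting 4-chloro-3-(trifluoromethyl)phenyl in place of 4-iodophenyl on the amide-type nitrogen gave an at least 3.9-fold lower number from compound 3 to compound 4 (0.59 log units; beyond the scatter). The change therefore lowered the number on both cores, and the two steps can be set side by side: the same change on two cores in this assay, a 3.7-fold lower number (0.57 log units; beyond the scatter) from compound 1 to compound 2 and an at least 3.9-fold lower number (0.59 log units; beyond the scatter) from compound 3 to compound 4; the limit leaves it open whether they differ Compound 3 stands at > 20000 nM, which is a limit of the assay and not a number, so these pairs show that the direction of the change carried over from one core to the other, but not that its size was the same, and two pairs set no rule for any further core.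

The compounds shown leave open how other groups on the amide-type nitrogen would compare with these two, for example a phenyl ring carrying a nitrile, an amine or a carboxylic acid in place of the halogens and the trifluoromethyl group. They also leave open whether the same exchange would lower the number again on a core with a longer chain, and whether it would do so in any setting other than this assay.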